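The source may report more compounds than this note shows. Statements on the series, on what has been measured and on what is new or still open speak of the compounds shown alone.

Measured so far:
compound 1 `CC1Cc2ccccc2N1S(=O)(=O)c1ccc(-c2cnc(C3CC3)o2)cc1`: 52.4%
compound 2 `Cc1ccc2c(c1)CCN2S(=O)(=O)c1ccc(-c2cnc(C3CC3)o2)cc1`: 63.4%

In a functional assay on A549 cells (Homo sapiens) for inhibition, read by MTT assay, tested at 10 uM (a lower number here means less inhibition, a higher number more inhibition at the concentration tested (going by the name of the read-out)), compound 2 gives 63.4%, the higher of the two numbers; compound 1 gives 52.4%, a step lower that lies beyond the scatter. Compound 3 `CS(=O)(=O)c1ccc2c(c1)CCN2S(=O)(=O)c1ccc(-c2cnc(C3CC3)o2)cc1` differs from compound 2 in one place: methylsulfonyl in place of methyl on an aromatic carbon. Among the compounds with values here, no step between measured compounds carries this change, so its size in this assay is unknown; with no guide, the expected step is none beyond the scatter, in either direction. For compound 3 the estimated value is 58% (range 30% to 82%), an expected step of a number 5.4 percentage points lower from compound 2 to compound 3 (within the scatter).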

Compound 3, a percentage reported as inhibition, at one concentration (the size of the read-out at that concentration, not a potency): 4.14%
Estimate against measurement, compound 3: 53.9 percentage points above; the measured number lies below the stated range.
By their numbers in this assay, from the lowest: compound 3; then compound 1; then compound 2.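

In this assay, replacing methyl with methylsulfonyl on this aromatic carbon gives a number 59.3 percentage points lower from compound 2 to compound 3 (beyond the scatter), so this position is sensitive to the group it carries. Within the data shown here, that sensitivity was not visible from the earlier compounds, which offered no step at this carbon. Nothing available accounts for the loss.

On these data alone, whether the loss is specific to methylsulfonyl remains open. An amine, a nitrile or a methoxy group on the same carbon could stay close to compound 2 or fall as far as compound 3.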